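Hydrazone aryl swap in the thiazolyl hydrazone series

The compounds below may be only part of what the source reports. "The series", "measured", "known", "first", "only" and "open" are said of these compounds alone.

Of the compounds shown here, two have numbers so far. Compound 1 `Fc1ccc(/C=N/Nc2nc(-c3cc(C(F)(F)F)cc(C(F)(F)F)c3)cs2)cc1F` in a functional assay on A549 cells (Homo sapiens) for inhibition, read by MTT assay, with a stated time of 48 h (a higher number here means a weaker inhibitor, a lower number a stronger inhibitor), gives 6230 nM and stands as the lowest of the two numbers. Compound 2 `COc1cc(/C=N/Nc2nc(-c3cccc(Br)c3)cs2)cc(Br)c1OC` in this assay gives 56000 nM, a gap beyond the scatter; the two differ in more than one place, so only their two values can be compared. Compound 3 `COc1cc(/C=N/Nc2nc(-c3cc(C(F)(F)F)cc(C(F)(F)F)c3)cs2)cc(Br)c1OC` is not yet measured in this assay. It differs from compound 1 by 3-bromo-4,5-dimethoxyphenyl in place of 3,4-difluorophenyl on a carbon with a double bond to nitrogen, which places on the core of compound 1 the same aryl hydrazone found in compound 2. Among the compounds with values here, no single-change step is available in this assay, so the size of the step is open; a step upward, toward a weaker inhibitor, is expected because compound 2 gives 56000 nM. Compound 3 in this assay is estimated at 15000 nM, between 4000 nM and 50000 nM, a step of a 2.4-fold higher number from compound 1 to compound 3 (0.38 log units; beyond the scatter) from compound 1.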

Compound 3, half-maximal inhibitory concentration: 94200 nM
Compound 3: the middle estimate sits 6.3-fold (0.80 log units) below what was measured, outside the stated range (above it).
By their numbers in this assay, from the lowest: compound 1; then compounds 2 and 3 (each within the scatter of the next).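

In this assay, within the data shown here, the only single-change step so far lies at the hydrazone aryl: 3-bromo-4,5-dimethoxyphenyl in place of 3,4-difluorophenyl on a carbon with a double bond to nitrogen gives a 15-fold higher number from compound 1 to compound 3 (1.18 log units; beyond the scatter), a large move toward a weaker inhibitor. With that same aryl hydrazone in place, compound 2 gives 56000 nM and compound 3 gives 94200 nM, values within the scatter of each other, so the remaining structural difference between these two does not separate them in this assay. No available measurement gives a reason for the step.

As far as these compounds go, the change brings in bromine and two methoxy groups together, so the share of each in the step remains open. Also open, from the compounds shown here alone, is how this position responds to an aryl bearing an amine or a carboxylic acid.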